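This account rests on a few compounds, and the source may have more. Where it says the series, first, only, none or still open, it means among the compounds named here.

Compound 1 `CC#C[C@@H](Cc1nnn[nH]1)c1ccc(OCc2ccc3scc(-c4cncnc4C)c3c2)cc1` carries a 4-methylpyrimidin-5-yl group on the shared core. In an ADME assay on microsomes from liver (Homo sapiens) for metabolic stability (a higher number here means that the compound lasts longer, a lower number that the compound disappears faster), compound 1 gives 0.233 h. Compound 2 `CC#C[C@@H](Cc1nnn[nH]1)c1ccc(OCc2ccc3scc(-c4ccccc4C(F)(F)F)c3c2)cc1` has 2-(trifluoromethyl)phenyl in that place. In this assay compound 2 reaches only a limit of the assay, < 0.0667 h. Compound 3 `CC#C[C@@H](Cc1nnn[nH]1)c1ccc(OCc2cc(C)c3scc(-c4ccccc4C)c3c2)cc1` likewise gives only a limit in this assay, < 0.0667 h. Compound 2 thus stands at the edge of what the assay reports, the same edge at which compound 3 sits (the limit of < 0.0667 h in this assay, at which 2 of the 3 values shown sit). For the measured compounds named here, the one measured step that leads to compound 2 is an at least 3.4-fold lower number from compound 1 to compound 2 (0.54 log units; beyond the scatter), a move from a numeric value onto that limit.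

Compound 4 `CC#C[C@@H](Cc1nnn[nH]1)c1ccc(OCc2ccc3scc(-c4ccc(OCCOC)cc4C)c3c2)cc1` differs from compound 2 in one group: 4-(2-methoxyethoxy)-2-methylphenyl in place of 2-(trifluoromethyl)phenyl on an aromatic carbon. Going by the values given here, no measured step swaps 2-(trifluoromethyl)phenyl for a group of this kind, so the comparison rests on compound 1, whose change to compound 2 was an at least 3.4-fold lower number from compound 1 to compound 2 (0.54 log units; beyond the scatter), and on compound 3 sitting at the same limit. A modest move back off the limit is expected, roughly an at least 1.4-fold higher number from compound 2 to compound 4 (0.17 log units; that floor lies within the scatter). Compound 4 is therefore estimated at 0.1 h in this assay, between 0.05 h and 0.25 h.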

Compound 4, half-life: 0.717 h
The estimate for compound 4 lay 7.2-fold (0.86 log units) below the measured number; the whole stated range lies below it.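

The position on the five-membered aromatic ring can hold a ring of carbon only and still give a higher number in this assay: placing 4-(2-methoxyethoxy)-2-methylphenyl there gives an at least 10-fold higher number from compound 2 to compound 4 (1.03 log units; beyond the scatter). From the compounds shown here alone, compound 2 holds only a limit of the assay, not a number, so the true size of that step stays unknown: the limit of < 0.0667 h in this assay, at which 2 of the 4 values shown sit. The new group also compares well with 4-methylpyrimidin-5-yl, with a 3.1-fold higher number from compound 1 to compound 4 (0.49 log units; beyond the scatter), so the earlier drop with 2-(trifluoromethyl)phenyl cannot be read as a general result for rings of carbon only at this position.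

Which part of 4-(2-methoxyethoxy)-2-methylphenyl accounts for the higher number stays open. Also open, going by these compounds, is whether a simple methoxy group, a longer ether chain or an amine in place of the 2-methoxyethoxy chain would give a similar number.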